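This account rests on a few compounds, and the source may have more. Where it says the series, first, only, none or still open, it means among the compounds named here.

Compound 1 `Nc1cc(N)c2nc(-c3ccccc3)c(NCc3ccc(F)cc3)nc2c1` gives 2630 nM in a functional assay on OVCAR-8 cells (Homo sapiens) for inhibition, read by sulforhodamine B assay, with a stated time of 48 h; on this read-out higher numbers stand for weaker inhibition of growth and lower numbers for stronger inhibition of growth. Compound 2 `COc1ccc(Sc2nc3cc(N)cc(N)c3nc2-c2ccccc2)cc1` gives only a limit in this assay, < 100000 nM. Compound 3 `Nc1cc(N)c2nc(-c3ccccc3)c(Oc3ccc(F)cc3)nc2c1` gives 22400 nM in this assay.

Compound 3 holds the highest of the two readable numbers; its nearest neighbour is compound 1, with an 8.5-fold higher number from compound 1 to compound 3 (0.93 log units; beyond the scatter). Compound 4 `Nc1cc(N)c2nc(-c3ccccc3)c(Sc3ccc(F)cc3)nc2c1` differs from compound 3 by (4-fluorophenyl)sulfanyl in place of 4-fluorophenoxy on an aromatic carbon. Among the compounds with values here, the one step measured with a number, an 8.5-fold higher number from compound 1 to compound 3 (0.93 log units; beyond the scatter), concerns a different exchange; the steps a step that the limit leaves unreadable from compound 1 to compound 2 and a step that the limit leaves unreadable from compound 2 to compound 3 cannot be read because of the limit of < 100000 nM in this assay, at which 1 of the 3 values shown sits. Within the data shown here, no measured step speaks directly to sulfur in place of oxygen here, so only a small shift is expected, a 1.1-fold higher number from compound 3 to compound 4 (0.05 log units; within the scatter). Compound 4 is therefore estimated at 25000 nM, within 6000 nM to 100000 nM.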

Compound 4, concentration for 50% growth inhibition: 16600 nM
Estimate against measurement, compound 4: 1.5-fold (0.18 log units) above; measured number inside the range.
By their numbers in this assay, from the lowest: compound 1; then compounds 4 and 3 (each within the scatter of the next).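

Exchanging 4-fluorophenoxy for (4-fluorophenyl)sulfanyl at this position gives a 1.3-fold lower number from compound 3 to compound 4 (0.13 log units; within the scatter), so the two groups are not told apart here. The (4-fluorobenzyl)amino group of compound 1 remains separate from this one as well, with a 6.3-fold higher number from compound 1 to compound 4 (0.80 log units; beyond the scatter), as it was from 4-fluorophenoxy. Compound 2 gives only a limit, so its step to compound 4 cannot be read: the limit of < 100000 nM in this assay, at which 1 of the 4 values shown sits.

Compound 1 differs from compounds 3 and 4 in both the atom attached to the core and the added methylene, and the compounds shown do not separate these two changes. A (4-fluorophenyl)amino group or a benzyloxy group at this position would bear on that question.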